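Ortho halogen swap on a quinazoline cinnamamide

The source may report more compounds than this note shows. Statements on the series, on what has been measured and on what is new or still open speak of the compounds shown alone.

An anilinoquinazoline bearing a cinnamamide was tested in a functional assay on A549 cells (Homo sapiens) for antiproliferative activity, read by MTT assay, with a stated time of 48 h; on this read-out lower numbers stand for stronger inhibition and higher numbers for weaker inhibition. Compound 1 `O=C(/C=C/c1ccc(Cl)cc1)Nc1ccc2ncnc(Nc3cccc(Cl)c3)c2c1` gave 12.4 ug/mL, while compound 2 `O=C(/C=C/c1ccccc1Cl)Nc1ccc2ncnc(Nc3cccc(Cl)c3)c2c1` gave 4.58 ug/mL. The single step shown, a 2.7-fold lower number from compound 1 to compound 2 (0.43 log units; beyond the scatter), moved the chlorine from the para to the ortho position of the phenyl ring. Within the data shown here, compound 2 thus stands lowest of the two numbers, with compound 1 as its only neighbour.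

Compound 3 `O=C(/C=C/c1ccccc1Br)Nc1ccc2ncnc(Nc3cccc(Cl)c3)c2c1` is not yet measured. It differs from compound 2 by bromo in place of chloro on an aromatic carbon. Among the measured compounds shown here, no measured step bears on a halogen exchange at the same position; the one step that exists concerns position, not the identity of the halogen. With nothing pointing either way, compound 3 is expected to sit within the scatter of compound 2, giving an estimated step of a 1.0-fold lower number from compound 2 to compound 3 (0.01 log units; within the scatter). Compound 3 is therefore estimated at 4.5 ug/mL, with a range from 2 ug/mL to 10 ug/mL.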

Compound 3, half-maximal inhibitory concentration: 5.63 ug/mL
Beside the measured number, compound 3's estimate is 1.3-fold (0.10 log units) below it; low and high end bracket the measured number.
By their numbers in this assay, from the lowest: compounds 2 and 3 (each within the scatter of the next); then compound 1.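

In this assay, bromo in place of chloro on an aromatic carbon gave a 1.2-fold higher number from compound 2 to compound 3 (0.09 log units; within the scatter), so this position did not separate the two halogens. The 2-bromophenyl group also held its advantage over the 4-chlorophenyl group, with a 2.2-fold lower number from compound 1 to compound 3 (0.34 log units; beyond the scatter), which shows that the lower number seen earlier for the 2-chlorophenyl group was not confined to chloro. No evidence is available that would account for this result.

The compounds shown leave open whether a fluoro, methyl or methoxy group at this same position would also stay within the scatter of chloro and bromo, or would depart from them. They also leave open whether a 4-bromophenyl group would stand as far from the 2-bromophenyl group as the 4-chlorophenyl group stands from the 2-chlorophenyl group.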